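The source may report more compounds than this note shows. Statements on the series, on what has been measured and on what is new or still open speak of the compounds shown alone.

Measured so far:

Compound 1, `O=C(Nc1cc(C(F)(F)F)cc(C(F)(F)F)c1)c1ccc(-c2ccccc2)cc1O`: 1240 nM
Compound 2, `O=C(Nc1cccc(C(F)(F)F)c1)c1cc(F)ccc1O`: 840 nM
Compound 3, `O=C(Nc1ccc(Cl)c(C(F)(F)F)c1)c1cc(F)ccc1O`: 530 nM

All three were tested in a functional assay on Jurkat cells (Homo sapiens) for cytotoxicity, read by luminescence and CellTiter-Glo, with a stated time of 3 days; a lower number here means a stronger inhibitor, a higher number a weaker inhibitor. Compound 1 gives the highest of the three numbers, but its value and that of compound 2 lie within the scatter of each other, so no order between them can be read. Only compound 3 stands beyond the scatter from compound 1. The difference between the core of compound 1 and the core of compound 2 is not broken down here.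

Between compound 2 and compound 3 there is one change, (chloro in place of hydrogen on an aromatic carbon). It produced a 1.6-fold lower number from compound 2 to compound 3 (0.20 log units; within the scatter).

The unmeasured compound 4, `O=C(Nc1cc(C(F)(F)F)cc(C(F)(F)F)c1)c1cc(Cl)c(-c2ccccc2)cc1O`, arises from compound 1 by chloro in place of hydrogen on an aromatic carbon. For the measured compounds named here, this is the same kind of change as the one from compound 2 to compound 3, not the same: there the chloro entered ortho to a trifluoromethyl group and para to a large group, whereas here it enters ortho to a phenyl group, meta to a large group and para to a hydroxy group. Going by the values given here, with only one example of this change, the expectation for compound 4 rests on that single step: a step of about the size of a 1.6-fold lower number from compound 2 to compound 3 (0.20 log units; within the scatter) is expected, which in this assay is a 1.5-fold lower number from compound 1 to compound 4 (0.16 log units; within the scatter). Compound 4 is therefore estimated to give 850 nM, with a likely range from 400 nM to 1800 nM.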

Compound 4, half-maximal inhibitory concentration: 540 nM
Beside the measured number, compound 4's estimate is 1.6-fold (0.20 log units) above it, and the stated range covers the measured number.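

In this assay, putting the chloro on the core of compound 1 gave a 2.3-fold lower number from compound 1 to compound 4 (0.36 log units; beyond the scatter), a modest step, but one that stands clear of the scatter on its own. Set beside the earlier step on the other core, it cannot be told apart in size: the same change on two cores in this assay, a 1.6-fold lower number (0.20 log units; within the scatter) from compound 2 to compound 3 and a 2.3-fold lower number (0.36 log units; beyond the scatter) from compound 1 to compound 4, 1.4-fold (0.16 log units) apart, within the scatter of two such steps. The result on one core is therefore compatible with the result on the other, even though the chloro sits at a different place in each, but two pairs are a small base, and they show neither that a step of this size would hold on a further core nor why the number moves.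

The compounds shown leave open whether a bromo, methyl or methoxy group at the same place on the core of compound 1 would give a number like that of compound 4, or whether an amine or a carboxylic acid there would give a very different one. They also leave open whether the chloro would give a similar step at the other free places on the ring that carries the hydroxy group, and what would follow if the phenyl group of compound 4 were replaced by a smaller group such as a methyl.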